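The source may report more compounds than this note shows. Statements on the series, on what has been measured and on what is new or still open speak of the compounds shown alone.

Measured in an ADME assay on the whole organism for inhibition, with Oryza sativa as the target, with a stated time of 4 days; on this read-out lower numbers stand for stronger inhibition and higher numbers for weaker inhibition:
- compound 1 `CCN(c1nc(Cl)nc(N[C@H](C)c2ccccc2)n1)C(C)C`: 3550 nM
- compound 2 `CC[C@@H](C)Nc1nc(Cl)nc(N[C@H](C)c2ccccc2)n1`: 8320 nM
- compound 3 `CC[C@@H](C)Nc1nc(Cl)nc(N[C@@H](C)c2ccccc2)n1`: 9770 nM

Compound 3 cannot be told apart from compound 2: the step of a 1.2-fold higher number from compound 2 to compound 3 (0.07 log units; within the scatter) is a change of configuration alone. Compound 1 shows a lower number than compound 3.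

Compound 4 `CCCN(CCC)c1nc(Cl)nc(N[C@@H](C)c2ccccc2)n1` carries dipropylamino in place of (sec-butyl)amino on an aromatic carbon. Among the compounds with values here, the one measured step at this place is a 2.3-fold higher number from compound 1 to compound 2 (0.37 log units; beyond the scatter), where (sec-butyl)amino replaced ethyl(isopropyl)amino. Read in reverse, it points to a modest drop in this assay, although dipropylamino itself is untested. The expected size is a 2.3-fold lower number from compound 3 to compound 4 (0.36 log units; beyond the scatter). For compound 4 the estimate is 4300 nM, with an expected range of 1900 nM to 9500 nM.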

Compound 4, half-maximal inhibitory concentration: 331 nM
Compound 4: the middle estimate sits 13-fold (1.11 log units) above what was measured; the whole stated range lies above it.
By their numbers in this assay, from the lowest: compound 4; then compound 1; then compounds 2 and 3 (each within the scatter of the next).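

In this assay, the amino group at this position matters far more than the earlier step suggested: a 30-fold lower number from compound 3 to compound 4 (1.47 log units; beyond the scatter). The change replaces (sec-butyl)amino, which has a hydrogen-bond donor, with the larger dipropylamino, which has none, and these differences arrive together, so neither can be credited alone. The change of configuration, by contrast, stayed within the scatter, a 1.2-fold higher number from compound 2 to compound 3 (0.07 log units; within the scatter), and that contrast rests on this: the fact that compounds 2 and 3 differ only in the configuration as drawn.

Still open, as far as these compounds go, is whether the longer chains of dibutylamino would lower the number further. Propylamino could show whether one propyl chain is enough.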